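The compounds below may be only part of what the source reports. "The series", "measured", "known", "first", "only" and "open" are said of these compounds alone.

Measured compounds in this series:
compound 1 `CS(=O)(=O)c1ccc(-c2nc3ccccn3c2Sc2ccccc2)cc1` — in an ADME assay on HEK293 cells (Homo sapiens) for inhibition, read by MTT assay, with a stated time of 48 h (a higher number here means a weaker inhibitor, a lower number a stronger inhibitor), compound 1 gives > 100000 nM, a limit of the assay.
compound 2 `COc1ccc(-c2nc3ccccn3c2Sc2ccccc2)cc1` — compound 2 gives > 100000 nM, again a limit.
compound 3 `N#Cc1ccc(-c2nc3ccccn3c2Sc2ccccc2)cc1` — compound 3 gives > 100000 nM, also a limit.

All three values sit at the limit of > 100000 nM in this assay, at which 3 of the 3 values shown sit, so compound 1 stands at the limit and nowhere more precisely. The steps a step that the two limits leave unreadable from compound 1 to compound 2, a step that the two limits leave unreadable from compound 1 to compound 3 and a step that the two limits leave unreadable from compound 2 to compound 3 are therefore unreadable in size and direction.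

Compound 4 `CS(=O)(=O)c1ccc(-c2nc3ccccn3c2Sc2cccc3ccccc23)cc1` differs from compound 1 by naphthalen-1-yl in place of phenyl on a sulfur. Within the data shown here, none of the measured steps touches the group on the sulfur; each varies only the group on the aromatic carbon, so no measured step bears directly on this change, and the three limits give no direction to lean on. Compound 4 is expected to remain at the limit, estimated at 150000 nM (range 50000 nM to 500000 nM); the expected step that the limit leaves unreadable from compound 1 to compound 4 is none beyond the scatter.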

Compound 4, half-maximal inhibitory concentration: 83200 nM
For compound 4 the middle estimate is 1.8-fold (0.26 log units) above the measured one; low and high end bracket the measured number.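

Among these compounds, with naphthalen-1-yl on the sulfur, this assay gives the first reading that is a number and not a limit, with an at least 1.2-fold lower number from compound 1 to compound 4 (0.07 log units; that floor lies within the scatter). On these data alone, the group on the sulfur is therefore a place where this series can leave the limit, though the true size of the step stays unknown. The rest of the series gives no further number: the limit of > 100000 nM in this assay, at which 3 of the 4 values shown sit.

As far as these compounds go, whether naphthalen-1-yl gives a readable value alongside the methoxy of compound 2 or the cyano of compound 3 remains open. Also open, from the compounds shown here alone, is how a benzyl group or a smaller alkyl chain on the sulfur would read.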